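Amide replacement on a naphthyl pyridine acrylamide

The source may hold more compounds than are shown below. What is called first, only, known or untested is meant among the compounds shown, and "the series" means these compounds.

Compound 1, `O=C(/C=C/c1ccncc1-c1ccc2ncccc2c1)N1CCOCC1`: 1590 nM
Compound 2, `COC1CN(C(=O)/C=C/c2ccncc2-c2ccc3ccccc3c2)C1`: 42.8 nM

In an assay on a protein complex for inhibition of CDK8/Cyclin C (Homo sapiens), with a stated time of 1 h (a lower number here means a stronger inhibitor, a higher number a weaker inhibitor), compound 2 gives the lower of the two numbers; compound 1 sits a long way higher, well beyond the scatter. Compound 3, `O=C(/C=C/c1ccncc1-c1ccc2ccccc2c1)NC1CC1`, carries cyclopropylamino in place of 3-methoxyazetidin-1-yl on a carbonyl carbon. For the measured compounds named here, no measured pair shows this change, so its effect is unknown. Compound 3 is expected to stay near compound 2 in this assay, the step of a 1.5-fold higher number from compound 2 to compound 3 (0.18 log units; within the scatter) being a small weakening within or just beyond the scatter. Compound 3 is estimated at 65 nM, with a range from 15 nM to 280 nM.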

Compound 3, half-maximal inhibitory concentration: 40.1 nM
For compound 3 the middle estimate is 1.6-fold (0.21 log units) above the measured one; measured number inside the range.
By their numbers in this assay, from the lowest: compounds 3 and 2 (each within the scatter of the next); then compound 1.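

In this assay, putting cyclopropylamino in place of 3-methoxyazetidin-1-yl on a carbonyl carbon gives a 1.1-fold lower number from compound 2 to compound 3 (0.03 log units; within the scatter). This position therefore tolerates a smaller group with a different ring, and the move from no hydrogen-bond donor to one, without a change beyond the scatter. Nothing on hand explains this result. Still open, going by these compounds, is whether an open-chain group such as dimethylamino or n-butylamino would keep the number within the scatter at this position. On these data alone, a carboxylic acid on a longer chain also remains untested here.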